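Ring methyl added to the core of compound 2

The source may hold more compounds than are shown below. What is called first, only, known or untested is meant among the compounds shown, and "the series" means these compounds.

Compound 1 `Cc1cc(C)c(S(=O)(=O)N2CCN(C3CN4CCC3CC4)CC2)c(C)c1` and compound 2 `CC1CCN(C2CCN(S(=O)(=O)c3cnc(Cl)s3)CC2)CC1` were tested in an ADME assay on HCT-116 cells (Homo sapiens) for cytotoxicity, read by CellTiter-Glo, with a stated time of 72 h; a higher number here means a weaker inhibitor, a lower number a stronger inhibitor. Compound 1 gives only a limit there, > 5000 nM. Compound 2 likewise gives only a limit, > 10000 nM. Going by the values given here, both values shown thus sit at limits, and no step between the two compounds is known. Compound 3 `Cc1nc(Cl)sc1S(=O)(=O)N1CCC(N2CCC(C)CC2)CC1` differs from compound 2 by methyl in place of hydrogen on an aromatic carbon, read one bond further out as 2-chloro-1,3-thiazol-5-yl to 2-chloro-4-methyl-1,3-thiazol-5-yl. Among the compounds with values here, no measured step informs this change. A step within the usual scatter is expected, a step that the limit leaves unreadable from compound 2 to compound 3. Compound 3 is expected at 20000 nM, between 8000 nM and 60000 nM, most likely again reported only as a limit.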

Compound 3, half-maximal inhibitory concentration: > 10000 nM
Compound 3 gave a limit, no number (the forecaster's own chance of this, stated with the estimate: 85%); the middle value does not contradict the limit.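

Compound 3 gives only a limit, > 10000 nM, and compound 2 also gives only a limit, so no step can be read from compound 2 to compound 3. As far as these compounds go, whether 2-chloro-4-methyl-1,3-thiazol-5-yl differs at all from 2-chloro-1,3-thiazol-5-yl in this read-out remains open.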